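Phenyl Directly on the Core in Place of Cyclohexylethyl

A few compounds are considered here, and "the series" means these few. Any claim that something is new, unique, unknown or untested is made for them only; others in the source may bear on it.

Measured compounds:
compound 1 `CCCCc1cnc(CCc2ccc(-c3ccccc3C(=O)O)cc2)[nH]1` gives 93 nM in an in vitro functional assay on cells for agonist activity at Bombesin receptor subtype-3 (Mus musculus), read by luminescence and calcium flux; a higher number here means that more compound is needed for the effect, a lower number that less compound is needed
compound 2 `O=C(O)c1ccccc1-c1ccc(CCc2ncc(CCC3CCCCC3)[nH]2)cc1` gives 33 nM in this assay

Compound 2 holds the lower of the two numbers in this assay; its nearest neighbour is compound 1, and the step of a 2.8-fold lower number from compound 1 to compound 2 (0.45 log units; beyond the scatter) lies beyond the scatter. Compound 3 `O=C(O)c1ccccc1-c1ccc(CCc2ncc(-c3ccccc3)[nH]2)cc1` has not yet been measured. It differs from compound 2 in one place: phenyl in place of 2-cyclohexylethyl on an aromatic carbon. Within the data shown here, the only measured step that bears on this position is a 2.8-fold lower number from compound 1 to compound 2 (0.45 log units; beyond the scatter), which showed that a larger saturated group on the chain gave a modestly lower number. Compound 3 instead removes the chain and the saturated ring altogether and sets a phenyl directly on the aromatic carbon, a change of a different kind from the one measured, so the direction is uncertain. Compound 3 is expected to give about 150 nM in this assay, with a range of 40 nM to 600 nM, which would mean a step of a 4.5-fold higher number from compound 2 to compound 3 (0.66 log units; beyond the scatter).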

Compound 3, half-maximal effective concentration: 872 nM
Estimate against measurement, compound 3: 5.8-fold (0.76 log units) below; the whole stated range lies below it.
By their numbers in this assay, from the lowest: compound 2; then compound 1; then compound 3.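

In this assay, phenyl in place of 2-cyclohexylethyl on this aromatic carbon gives a 26-fold higher number from compound 2 to compound 3 (1.42 log units; beyond the scatter) and phenyl in place of butyl gives a 9.4-fold higher number from compound 1 to compound 3 (0.97 log units; beyond the scatter) in the same direction. Both steps are larger than the one between the two saturated groups, a 2.8-fold lower number from compound 1 to compound 2 (0.45 log units; beyond the scatter) and this shows that a phenyl directly on this carbon stands well apart from both of them. Nothing given here accounts for this result.

Compound 3 replaces the saturated ring with an aromatic one and removes the chain in a single change, and the compounds shown cannot separate these two differences. From the compounds shown here alone, a 2-phenylethyl group or a cyclohexyl set directly on this carbon would separate them, and how a longer chain would read here also remains open.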